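The source may report more compounds than this note shows. Statements on the series, on what has been measured and on what is new or still open speak of the compounds shown alone.

The series rests on one shared core, varied only at the group attached to the carbonyl carbon of the amide. Compound 1 `O=C(NC1CCC(=Cc2cccc(Oc3ccc(C(F)(F)F)cn3)c2)CC1)c1cccnc1` carries a plain pyridin-3-yl there, and in an assay for inhibition of Fatty-acid amide hydrolase 1 (Rattus norvegicus), read by fluorescence, with stated times of 1 min and 50 min (on this read-out lower numbers stand for stronger inhibition and higher numbers for weaker inhibition), compound 1 gives 13 nM. Compound 2 `O=C(NC1CCC(=Cc2cccc(Oc3ccc(C(F)(F)F)cn3)c2)CC1)c1ccccn1` carries a pyridin-2-yl instead; in this assay compound 2 is recorded as "not determined" (no result reported), so no number is available for it. Compound 3 `Nc1ncc(C(=O)NC2CCC(=Cc3cccc(Oc4ccc(C(F)(F)F)cn4)c3)CC2)cc1Cl` carries a 6-amino-5-chloropyridin-3-yl, and in this assay compound 3 gives 52 nM, the higher of the two numbers available, which here means the weaker inhibition: a 4.0-fold higher number from compound 1 to compound 3 (0.60 log units; beyond the scatter).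

Compound 4 `O=C(NC1CCC(=Cc2cccc(Oc3ccc(C(F)(F)F)cn3)c2)CC1)c1ccc(-n2cccn2)nc1` arises from compound 3 by the change (6-(1H-pyrazol-1-yl)pyridin-3-yl in place of 6-amino-5-chloropyridin-3-yl on a carbonyl carbon). Among the compounds with values here, the only measured step that bears on it is a 4.0-fold higher number from compound 1 to compound 3 (0.60 log units; beyond the scatter), which shows that substituting the pyridin-3-yl on this carbonyl carbon raised the number modestly. Compound 4 carries a different and larger substituent on the same ring, so the direction of the step from compound 3 is uncertain; the expectation is a partial return toward the number of compound 1, a modest lowering, estimated as a 2.1-fold lower number from compound 3 to compound 4 (0.32 log units; beyond the scatter). For compound 4 in this assay the estimate is 25 nM, with a likely range from 7 nM to 90 nM.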

Compound 4, half-maximal inhibitory concentration: 6.6 nM
The estimate for compound 4 lay 3.8-fold (0.58 log units) above the measured number, outside the stated range (below it).
By their numbers in this assay, from the lowest: compounds 4 and 1 (each within the scatter of the next); then compound 3.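

The rise seen with compound 3 does not hold for every substituted pyridin-3-yl in this assay: the move to the 6-(1H-pyrazol-1-yl)pyridin-3-yl brings a 7.9-fold lower number from compound 3 to compound 4 (0.90 log units; beyond the scatter) and so undoes that rise. Set against the plain pyridin-3-yl, the 1H-pyrazol-1-yl in place of hydrogen on an aromatic carbon gives a 2.0-fold lower number from compound 1 to compound 4 (0.29 log units; within the scatter) so a substituent that adds a whole five-membered aromatic ring leaves the number indistinguishable from that of the unsubstituted ring, and the higher number of compound 3 therefore belongs to its own 6-amino-5-chloropyridin-3-yl and not to substitution as such. No data here explain why the two substituted rings differ.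

The step from compound 3 to compound 4 swaps the whole ring substituent pattern in one move, so the shares of the amino group, the chlorine and the pyrazole in the change cannot be separated. As far as these compounds go, it also remains open how this position responds to other groups at the same place on the ring, such as a morpholine ring, a carboxylic acid or a simple methoxy group.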